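From furan-3-yl to ethynyl on a shared core

This account rests on a few compounds, and the source may have more. Where it says the series, first, only, none or still open, it means among the compounds named here.

In a functional assay on K562 cells (Homo sapiens), read by MTT assay, with a stated time of 72 h (a lower number here means a stronger inhibitor, a higher number a weaker inhibitor), compound 1 `C#Cc1cn([C@@H]2O[C@H](CO)[C@@H](O)[C@H]2O)c2ncnc(N(C)C)c12` gives 110 nM as its reading. Compound 2 `Cc1ncnc2c1c(-c1ccoc1)cn2[C@@H]1O[C@H](CO)[C@@H](O)[C@H]1O` stands at > 20000 nM in this assay and that is a limit, not a number. Compound 3 `C#Cc1cn([C@@H]2O[C@H](CO)[C@@H](O)[C@H]2O)c2ncnc(C)c12` has ethynyl in place of furan-3-yl on an aromatic carbon and otherwise matches compound 2. Within the data shown here, no measured pair shows this change alone, but compound 1 also carries ethynyl and gives 110 nM in this test, so a large move towards stronger inhibition is expected. The expected change is an at least 66-fold lower number from compound 2 to compound 3 (1.82 log units; beyond the scatter) on this estimate. Compound 3 is estimated at 300 nM (range 40 nM to 2500 nM).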

Compound 3, half-maximal inhibitory concentration: 6920 nM
Compound 3: the middle estimate sits 23-fold (1.36 log units) below what was measured; the whole stated range lies below it.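

In this assay, ethynyl gives a stronger reading than furan-3-yl at this position, with an at least 2.8-fold lower number from compound 2 to compound 3 (0.46 log units; beyond the scatter). The true size of this step stays unknown because compound 2 is held at a limit, not a number: the limit of > 20000 nM in this assay, at which 1 of the 3 values shown sits.
Ethynyl alone does not set the reading, however: with methyl in place of dimethylamino there is a 63-fold higher number from compound 1 to compound 3 (1.80 log units; beyond the scatter).

On these data alone, whether a longer alkyne chain in place of ethynyl would change the reading remains open. So does the effect of a primary amine in place of dimethylamino.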